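The source may report more compounds than this note shows. Statements on the series, on what has been measured and on what is new or still open speak of the compounds shown alone.

Compound 1, `O=C(Nc1ccccc1)c1ccc(/N=N\c2c[nH]c3ccccc23)cc1`: 103000 nM
Compound 2, `Cc1ccc(C)c(NC(=O)c2ccc(/N=N\c3c[nH]c4ccccc34)cc2)c1`: 544000 nM

In a functional assay on HCT-116 cells (Homo sapiens) for inhibition, read by MTT assay, with a stated time of 72 h (a lower number here means a stronger inhibitor, a higher number a weaker inhibitor), compound 2 gives the higher of the two measured numbers, 544000 nM, while compound 1 gives 103000 nM. Compound 3, `Cc1ccccc1NC(=O)c1ccc(/N=N\c2c[nH]c3ccccc23)cc1`, still awaits measurement in this assay. From compound 2 to compound 3 the change is hydrogen in place of methyl on an aromatic carbon. Among the measured compounds shown here, the only measured step that bears on this runs the opposite way: a 5.3-fold higher number from compound 1 to compound 2 (0.72 log units; beyond the scatter). Taking away one methyl is expected to undo part of that step, so a lower number is expected for compound 3, roughly a 2.4-fold lower number from compound 2 to compound 3 (0.37 log units; beyond the scatter). Compound 3 is therefore estimated at 230000 nM, with a range from 100000 nM to 550000 nM.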

Compound 3, half-maximal inhibitory concentration: 509000 nM
Estimate against measurement, compound 3: 2.2-fold (0.34 log units) below; the measured number falls inside the stated range.
By their numbers in this assay, from the lowest: compound 1; then compounds 3 and 2 (each within the scatter of the next).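

In this assay the change from 2,5-dimethylphenyl to 2-methylphenyl gives a 1.1-fold lower number from compound 2 to compound 3 (0.03 log units; within the scatter) and so the methyl para to a methyl group makes no readable difference here. A single methyl on the phenyl ring already gives a 4.9-fold higher number from compound 1 to compound 3 (0.69 log units; beyond the scatter) and so the weaker result seen with two methyls is already present with one. As far as these compounds go, whether a methoxy group or a chlorine atom in place of the remaining methyl would give the same result stays open. The data shown give no evidence for the reason behind these steps.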